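Pyrimidin-5-yl in Place of 4-Methoxyphenyl

This account rests on a few compounds, and the source may have more. Where it says the series, first, only, none or still open, it means among the compounds named here.

Of the compounds shown here, three have so far been measured in a functional assay for agonist activity at G protein-coupled receptor 88 (Homo sapiens), read by HTRF and cAMP accumulation; a higher number here means that more compound is needed for the effect, a lower number that less compound is needed. Compound 1 `CC(C)C[C@H](N)CCN(C(=O)[C@@H]1C[C@H]1c1ccccc1)c1ccc(-c2ccccc2)cc1` gives 3 nM, and compound 2 `CCC(C)CNCCN(C(=O)[C@@H]1C[C@H]1c1ccccc1)c1ccc(-c2ccccc2)cc1` gives 4.7 nM; the step of a 1.6-fold higher number from compound 1 to compound 2 (0.19 log units; within the scatter) alters only the amine-bearing chain. Compound 3 `CC[C@H](C)[C@H](N)CN(C(=O)[C@@H]1C[C@H]1c1ccc(OC)cc1)c1ccc(-c2ccccc2)cc1` returns only a limit of the assay, > 25000 nM, so its true value is not known. That limit is the one at the limit of > 25000 nM in this assay, at which 1 of the 3 values shown sits. Compound 4 `CC[C@H](C)[C@H](N)CN(C(=O)[C@@H]1C[C@H]1c1cncnc1)c1ccc(-c2ccccc2)cc1` differs from compound 3 by pyrimidin-5-yl in place of 4-methoxyphenyl on a saturated ring carbon. Going by the values given here, no measured step touches this part of the molecule; the single measured step concerns the chain, not the ring, so the direction and size of an at least 1.2-fold lower number from compound 3 to compound 4 (0.09 log units; that floor lies within the scatter) remain an expectation without support. Compound 4 is estimated at 20000 nM, within a range from 3000 nM to 60000 nM, with a fair chance that the assay again reports only a limit.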

Compound 4, half-maximal effective concentration: 19000 nM
Compound 4: the middle estimate sits 1.1-fold (0.02 log units) above what was measured; the measured number falls inside the stated range.
By their numbers in this assay, from the lowest: compounds 1 and 2 (each within the scatter of the next); then compound 4. At a limit, above all of these: compound 3.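

Going by these compounds alone, the only measured change at this place on the three-membered ring is an at least 1.3-fold lower number from compound 3 to compound 4 (0.11 log units; that floor lies within the scatter) and, being a floor, it shows no real change. The value of compound 3 is a limit, not a number: the limit of > 25000 nM in this assay, at which 1 of the 4 values shown sits. Compound 4 at 19000 nM does give a true number with a group at this place, so further changes here can be read against it. Going by these compounds, the true size of the step stays unknown. Also open, on these data alone, is whether pyridin-3-yl or cyclohexyl here, on the chain of compound 4, would give a lower number.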